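Working notes on the shared core: from compound 3 to compound 4

The compounds below may be only part of what the source reports. "The series", "measured", "known", "first", "only" and "open" are said of these compounds alone.

Compound 1 `C[Si](C)(C)c1ccc2nc(N)sc2c1` gives 5 mg/kg in a functional assay on the whole organism with Rattus norvegicus as the target; a higher number here means that more compound is needed for the effect, a lower number that less compound is needed. In this assay compound 2 `CCC(C)(C)c1ccc2nc(N)sc2c1` reaches only a limit, > 10 mg/kg, and not a number. Among the measured compounds shown here, the single step between measured compounds, an at least 2.0-fold higher number from compound 1 to compound 2 (0.30 log units; that floor lies within the scatter), sits on an aromatic carbon of the shared core, as far as the limit allows it to be read (the limit of > 10 mg/kg in this assay, at which 1 of the 3 values shown sits). Compound 3 `C#CCn1c(=N)sc2cc(OC(F)(F)F)ccc21` gives 4 mg/kg in this assay, the lowest of the two numbers; compound 1 lies within the scatter of it, so no order between the two can be claimed.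

Compound 4 `CSCCn1c(=N)sc2cc(OC(F)(F)F)ccc21` differs from compound 3 by (methylsulfanyl)methyl in place of ethynyl on a saturated chain carbon bound to an aromatic nitrogen. For the measured compounds named here, no measured step touches the saturated chain on the aromatic nitrogen, and the step from compound 1 to compound 2 concerns another part of the core, so nothing measured bears on this change. The expected step in this assay is therefore a 1.1-fold higher number from compound 3 to compound 4 (0.05 log units; within the scatter), within the scatter, in no set direction. Compound 4 is expected to give 4.5 mg/kg, with a range from 2 mg/kg to 10 mg/kg.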

Compound 4, dose for half-maximal effect: 1 mg/kg
Estimate against measurement, compound 4: 4.5-fold (0.65 log units) above, outside the stated range (below it).
By their numbers in this assay, from the lowest: compound 4; then compounds 3 and 1 (each within the scatter of the next). At a limit, above all of these: compound 2.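

The saturated chain on the aromatic nitrogen is not a silent position in this assay: propargyl to 2-(methylsulfanyl)ethyl gives a 4.0-fold lower number from compound 3 to compound 4 (0.60 log units; beyond the scatter) and so marks this chain as a place where the number moves beyond the scatter. The change removes the triple bond and brings in a sulfur-bearing chain with one hydrogen-bond acceptor, and both alterations arrive together in this single step. Nothing measured here connects the step to any property of either group.

Going by these compounds, whether the sulfur is needed, or the longer chain alone is enough, stays open: a plain butyl chain or a 2-methoxyethyl chain would separate the two. Also open, on these data alone, is how an amine or a carboxylic acid at the end of this chain would read.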